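A few compounds are considered here, and "the series" means these few. Any claim that something is new, unique, unknown or untested is made for them only; others in the source may bear on it.

Measured in a functional assay on CHO cells for agonist activity at Alpha-1A adrenergic receptor (Homo sapiens), read by FLIPR and calcium flux; on this read-out higher numbers stand for larger maximal responses and lower numbers for smaller maximal responses:
compound 1 `CCCS(=O)(=O)Nc1cccc2c1CCC2c1ncc[nH]1` gives 54%
compound 2 `Cn1ccc(-c2cccc3c2CCC3c2ncc[nH]2)n1` gives 19%
compound 3 `Cn1nccc1-c1cccc2c1CCC2c1ncc[nH]1` gives 58%

Compound 3 holds the top number of the three, but compound 1 sits within the scatter of it, so the two cannot be ranked; only compound 2 lies clearly lower, the gap being a number 39 percentage points higher from compound 2 to compound 3 (beyond the scatter). The other steps at this position are a number 35 percentage points lower from compound 1 to compound 2 (beyond the scatter) and a number 4 percentage points higher from compound 1 to compound 3 (within the scatter), so the substituent on this aromatic carbon can move the maximal response a long way or hardly at all.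

Compound 4 `c1ccc2c(c1)CCC2c1ncc[nH]1` differs from compound 3 in hydrogen in place of 1-methyl-1H-pyrazol-5-yl on an aromatic carbon. Going by the values given here, no measured step removes a substituent at this site altogether, so none bears directly on the change; the measured steps only show that this site tolerates quite different groups with outcomes spread from weak to moderate. A change of either sign beyond the scatter in this assay is therefore possible, and the expectation is set near the middle of the observed spread. For compound 4 the estimated maximal response in this assay is 40% (range 12% to 72%), an expected step of a number 18 percentage points lower from compound 3 to compound 4 (beyond the scatter).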

Compound 4, largest response reached (Emax), in percent of the reference or control that the assay uses: 54%
Compound 4: middle estimate off by 14 percentage points, on the low side; low and high end bracket the measured number.
By their numbers in this assay, from the lowest: compound 2; then compounds 1, 4 and 3 (each within the scatter of the next).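

Hydrogen on this aromatic carbon gives, in this assay, a number 4 percentage points lower from compound 3 to compound 4 (within the scatter) and no change at the digits printed from compound 1 to compound 4 (within the scatter) when it replaces 1-methyl-1H-pyrazol-5-yl and (propylsulfonyl)amino in turn. Among these four compounds, a substituent at this site is therefore not needed for this level of maximal response. Replacing 1-methyl-1H-pyrazol-3-yl with hydrogen gives a number 35 percentage points higher from compound 2 to compound 4 (beyond the scatter) and thus sets this one group apart as the only substituent shown with a lower response than the unsubstituted compound.

As far as these compounds go, whether a fluorine atom, a methoxy group or a primary amine on this carbon would stay level with hydrogen or fall like 1-methyl-1H-pyrazol-3-yl remains open. Nothing at hand explains why the two methylpyrazole groups differ or why only one lies beyond the scatter from hydrogen.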